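This account rests on a few compounds, and the source may have more. Where it says the series, first, only, none or still open, it means among the compounds named here.

Compound 1 `COc1ccc(/C(=N/O)c2cccc3ccccc23)c(OC)c1OC`: 5880 nM
Compound 2 `COc1ccc(C(OCc2ccccc2)c2cccc3ccccc23)c(OC)c1OC`: > 20000 nM
Compound 3 `COc1cc(COC(c2ccc(OC)c(OC)c2OC)c2cccc3ccccc23)cc(OC)c1`: > 20000 nM

All three values come from a functional assay on HCT-116 cells (Homo sapiens) for inhibition, read by sulforhodamine B assay, with a stated time of 48 h; on this read-out higher numbers stand for weaker inhibition and lower numbers for stronger inhibition. For compound 2 the assay reports only a limit, > 20000 nM, not a number. Compound 3 likewise stops at a limit, so the picture is the limit of > 20000 nM in this assay, at which 2 of the 3 values shown sit. Compound 1 alone gives a number. Going by the values given here, the one single-change step among them, a step that the two limits leave unreadable from compound 2 to compound 3, has limits at both ends and cannot be read. Compound 4 `COc1ccc(C(c2ccc(OCC(=O)O)cc2)c2cccc3ccccc23)c(OC)c1OC` differs from compound 2 by 4-(carboxymethoxy)phenyl in place of benzyloxy on a saturated chain carbon bound to two aromatic carbons. Among the compounds with values here, no measured step resembles this change, and the starting point is itself a limit, so neither size nor direction can be drawn from the data. Compound 4 is therefore estimated at 15000 nM (range 3000 nM to 40000 nM), an expected step of an at least 1.3-fold lower number from compound 2 to compound 4 (0.12 log units; that floor lies within the scatter) in this assay.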

Compound 4, half-maximal inhibitory concentration: 5020 nM
Compound 4: middle estimate off by 3.0-fold (0.48 log units), on the high side, within the range that was stated.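

In this assay, replacing the benzyloxy group with the 4-(carboxymethoxy)phenyl group gives an at least 3.9-fold lower number from compound 2 to compound 4 (0.60 log units; beyond the scatter). Going by these compounds alone, this is the first readable sign that a change at this position can alter the read-out, as the one earlier single-change step cannot be read. For compound 2, > 20000 nM is a limit, not a number.

As far as these compounds go, it remains open whether the carboxymethoxy group or the new attachment of the ring accounts for the step. From the compounds shown here alone, whether an amine or a longer chain in place of the carboxymethoxy group would give a similar step also remains open.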